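Swapping a dichlorophenyl for a hydroxyphenyl on the shared core

The source may hold more compounds than are shown below. What is called first, only, known or untested is meant among the compounds shown, and "the series" means these compounds.

Compound 1 `COc1cc(-n2cnc3ccc(-c4cc(F)ccc4F)cc32)cc(OC)c1OC`: 6590 nM
Compound 2 `COc1ccc(-c2ccc3ncn(-c4cc(OC)c(OC)c(OC)c4)c3c2)cc1`: 82 nM
Compound 3 `COc1cc(-n2cnc3ccc(-c4ccc(Cl)cc4Cl)cc32)cc(OC)c1OC`: > 10000 nM

All three compounds share one core and differ only in the aryl group attached to it. In a functional assay on SGC-7901 cells (Homo sapiens) for antiproliferative activity, read by MTT assay, with a stated time of 72 h (a lower number here means a stronger inhibitor, a higher number a weaker inhibitor), compound 2 gives 82 nM and compound 1 gives 6590 nM. For compound 3 this assay reports only a limit, > 10000 nM, so no number is known for it. Compound 3 therefore sits at the limit of > 10000 nM in this assay, at which 1 of the 3 values shown sits, the weakest point on the scale that can be stated.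

Among the measured steps, an 80-fold lower number from compound 1 to compound 2 (1.91 log units; beyond the scatter), while an at least 120-fold higher number from compound 2 to compound 3 (2.08 log units; beyond the scatter) and an at least 1.5-fold higher number from compound 1 to compound 3 (0.18 log units; that floor lies within the scatter). Among the compounds with values here, the one group without halogens, 4-methoxyphenyl, thus stands far ahead of both halogenated groups.

Compound 4 `COc1cc(-n2cnc3ccc(-c4cccc(O)c4)cc32)cc(OC)c1OC` carries the change (3-hydroxyphenyl in place of 2,4-dichlorophenyl on an aromatic carbon). Within the data shown here, the step that bears most on it is the one from compound 2 to compound 3, in which a dichlorophenyl replaced a single-substituted, oxygen-bearing phenyl and the number rose sharply; compound 4 reverses that kind of change. A large step downward in this assay is therefore expected from compound 3 to compound 4, an at least 33-fold lower number from compound 3 to compound 4 (1.52 log units; beyond the scatter). Compound 4 is estimated at 300 nM, with a range from 60 nM to 3000 nM.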

Compound 4, half-maximal inhibitory concentration: 53 nM
For compound 4 the middle estimate is 5.7-fold (0.75 log units) above the measured one; the whole stated range lies above it.
By their numbers in this assay, from the lowest: compounds 4 and 2 (each within the scatter of the next); then compound 1. At a limit, above all of these: compound 3.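

The 3-hydroxyphenyl group shows that 4-methoxyphenyl is not alone at the strong end of this assay at this position: with a 1.5-fold lower number from compound 2 to compound 4 (0.19 log units; within the scatter), the two groups cannot be told apart, although one carries a hydroxyl and the other a methoxy. Both halogenated groups remain far behind, with a 120-fold lower number from compound 1 to compound 4 (2.09 log units; beyond the scatter) and an at least 180-fold lower number from compound 3 to compound 4 (2.27 log units; beyond the scatter), so the earlier contrast between halogenated and halogen-free aryl groups now rests on two different oxygen-bearing phenyl groups rather than one. Compound 3 is known only through a limit, so the second of those two steps is only a floor: the limit of > 10000 nM in this assay, at which 1 of the 4 values shown sits.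

Whether the oxygen substituent itself accounts for this contrast stays open, and a plain phenyl group would be the direct reference for that question. It is also open how this position would respond to a phenyl group carrying an amine, a carboxylic acid or a longer alkoxy chain, since the compounds shown cover only hydroxyl, methoxy, fluorine and chlorine on the ring.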